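This account rests on a few compounds, and the source may have more. Where it says the series, first, only, none or still open, it means among the compounds named here.

Measured in a physicochemical assay for lipophilicity, at pH 7.4; a higher number here means a more lipophilic compound, a lower number a more polar compound:

Compound 1 `CNC(=O)c1cc(C(=O)N[C@H]2[C@@H]3COC[C@@H]32)cc2c1OC[C@H]2c1cccnc1`: 1.4
Compound 2 `CNC(=O)c1cc(C(=O)N[C@H]2[C@@H]3COC[C@@H]32)cc2c1OC[C@H]2c1ccccc1`: 3.3

Among the measured compounds shown here, compound 2, at 3.3, holds the higher number of this pair, and compound 1 is its only neighbour. Compound 3 `CNC(=O)c1cc(C(=O)N[C@H]2[C@@H]3COC[C@@H]32)cc2c1OC[C@H]2c1ccncc1` has not yet been measured. It keeps the shared core and differs from compound 2 by one exchange: pyridin-4-yl in place of phenyl on a saturated ring carbon. Pyridin-4-yl takes the place of phenyl on a saturated ring carbon, two ring bonds from the ring oxygen.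

For the measured compounds named here, one measured step bears on this exchange: a number 1.90 log units higher from compound 1 to compound 2 (beyond the scatter). That step is large and beyond the scatter, and it swaps pyridin-3-yl for phenyl on the same saturated ring carbon. The exchange leading to compound 3 runs the other way, from phenyl to a pyridinyl group. Going by the values given here, no compound with pyridin-4-yl has been measured, so the transfer from pyridin-3-yl remains untested. A large step downward in this assay is therefore expected, of about the size seen with compound 1 at 1.4. The estimated step is a number 1.90 log units lower from compound 2 to compound 3 (beyond the scatter). For compound 3 the expected value is 1.4, within an estimated range from 1 to 1.9.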

Compound 3, distribution coefficient: 1.3
Beside the measured number, compound 3's estimate is 0.10 log units above it; the range from low to high includes it.
By their numbers in this assay, from the lowest: compounds 3 and 1 (each within the scatter of the next); then compound 2.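

In this assay the exchange of phenyl for pyridin-4-yl on the saturated ring carbon gives a number 2.00 log units lower from compound 2 to compound 3 (beyond the scatter) and so shows that a large downward step at this position is not confined to pyridin-3-yl, the only pyridinyl group earlier compounds had shown there. The exchange of pyridin-3-yl for pyridin-4-yl gives a number 0.10 log units lower from compound 1 to compound 3 (within the scatter) and so shows that, on this core and at this position, this assay does not separate the two pyridinyl groups: the large difference lies between phenyl and either of them, while the choice between the two leaves the read-out within the scatter. The data offered here give no measured ground on which to explain either step.

The compounds shown leave open whether pyridin-2-yl, or a phenyl ring carrying an amine or a carboxylic acid, would stand with the two pyridinyl compounds, with compound 2 or somewhere else on this scale. They also leave open whether the same exchanges would give steps of this size at another position or on a different core.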